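Chloro removal on the pyrazolyl-bearing ring of compound 2

The compounds below may be only part of what the source reports. "The series", "measured", "known", "first", "only" and "open" are said of these compounds alone.

For the measured compounds named here, compound 2 `Clc1ccc2c(c1-c1ccn[nH]1)CCC2c1ncc[nH]1` gives 322 nM in a functional assay on CHO cells for agonist activity at Alpha-1A adrenergic receptor (Homo sapiens), read by FLIPR and calcium flux; a higher number here means that more compound is needed for the effect, a lower number that less compound is needed; compound 1 `COc1c(Cl)ccc2c1CCC2c1ncc[nH]1` gives 451 nM there, the two within the scatter of each other, and the single step of a 1.4-fold lower number from compound 1 to compound 2 (0.15 log units; within the scatter) is the only one-place step measured. Compound 3 `CS(=O)(=O)Nc1cccc2c1CCCC2c1ncc[nH]1` gives 2150 nM; 142 nM; 234 nM (3 entries), a spread recorded as the several entries of compound 3 in this assay, 2150 nM; 142 nM; 234 nM (3 entries) that shows how far repeated readings of one compound can lie apart. The step to compound 4 `c1cc(-c2ccn[nH]2)c2c(c1)C(c1ncc[nH]1)CC2` is hydrogen in place of chloro on an aromatic carbon. Going by the values given here, no measured step removes a chloro, so the step of a 1.4-fold lower number from compound 1 to compound 2 (0.15 log units; within the scatter) does not bear on it directly. A modest rise beyond the scatter is expected for compound 4, a 2.0-fold higher number from compound 2 to compound 4 (0.31 log units; beyond the scatter), with the broad uncertainty the compound 3 entries suggest. Compound 4 is estimated at 650 nM, between 220 nM and 2000 nM.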

Compound 4, half-maximal effective concentration: 52 nM
Compound 4: the middle estimate sits 13-fold (1.10 log units) above what was measured, outside the stated range (below it).
By their numbers in this assay, from the lowest: compound 4; then compounds 2 and 1 (each within the scatter of the next).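

For the compounds shown here, compounds 1 and 2 both carry the chloro, so only this pair reads the aromatic carbon ortho to the 1H-pyrazol-5-yl group with and without it. In this assay, hydrogen in place of chloro gives a step beyond the scatter (a 6.2-fold lower number from compound 2 to compound 4 (0.79 log units; beyond the scatter)), so the chloro is not required for the effect at this position. The step still rests on single readings, and repeated readings of one compound can lie far apart: the several entries of compound 3 in this assay, 2150 nM; 142 nM; 234 nM (3 entries).

From the compounds shown here alone, whether fluoro, methyl or an amine at this carbon would keep the lower number remains open. Also open, going by these compounds, is whether the same change would give a similar step with methoxy in place of the 1H-pyrazol-5-yl group.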